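The source may report more compounds than this note shows. Statements on the series, on what has been measured and on what is new or still open speak of the compounds shown alone.

Compound 1 `Cn1c(CN2C[C@@H]3C(COc4ccccc4)[C@@H]3C2)nc2ccccc21` is the reference point of the series. In an in vitro assay on HEK293 cells with metabotropic glutamate receptor 2 (Rattus norvegicus) as the target, read by FLIPR, in the presence of a further agent that is not named here (on this read-out lower numbers stand for an effect already at smaller amounts and higher numbers for an effect only at larger amounts of compound), compound 1 gives 24 nM, the lowest of the two numbers measured. Among the compounds with values here, compound 3 `c1ccc(OCC2[C@H]3CN(Cc4nc5ccccc5n4C4CC4)C[C@@H]23)cc1` gives 3020 nM in this assay; the step of a 130-fold higher number from compound 1 to compound 3 (2.10 log units; beyond the scatter) is the only step measured between compounds that differ in one place, and it concerns the group on the aromatic nitrogen of the core. Compound 2 `c1ccc(OCC2[C@H]3CN(Cc4nc5ccccc5s4)C[C@@H]23)cc1` reaches only the limit of the assay in this assay, > 10000 nM. That value is the limit of > 10000 nM in this assay, at which 1 of the 3 values shown sits.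

Compound 4 `Cn1c(CN2C[C@@H]3C(COc4ccc(Cl)cc4F)[C@@H]3C2)nc2ccccc21` has not yet been measured. Within the data shown here, it differs from compound 1 by 4-chloro-2-fluorophenyl in place of phenyl on an oxygen on a saturated carbon, on the other side of the core from the change covered by the measured step, so no measured step bears on it directly. From compound 1 the step of a 1.6-fold lower number from compound 1 to compound 4 (0.20 log units; within the scatter) is expected to stay within or near the scatter, as nothing measured points in either direction. Compound 4 is therefore estimated at 15 nM in this assay, with a range from 5 nM to 60 nM.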

Compound 4, half-maximal effective concentration: 8 nM
Compound 4: middle estimate off by 1.9-fold (0.27 log units), on the high side; the range from low to high includes it.
By their numbers in this assay, from the lowest: compound 4; then compound 1; then compound 3. At a limit, above all of these: compound 2.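

In this assay the change from phenoxy to 4-chloro-2-fluorophenoxy gives a 3.0-fold lower number from compound 1 to compound 4 (0.48 log units; beyond the scatter) and is the first change shown that lowers the number from compound 1, so this end of the molecule accepts a chlorine and a fluorine on the phenyl ring without loss. The only step measured on the other side of the core, a 130-fold higher number from compound 1 to compound 3 (2.10 log units; beyond the scatter) in the same notes, runs the opposite way, which makes the phenoxy end the more promising place for further changes among the compounds shown. Nothing at hand bears on why the number falls with this change.

The chlorine and the fluorine enter together, so 4-chlorophenyl or 2-fluorophenyl alone could carry all, part or none of the step. From the compounds shown here alone, whether the phenyl also accepts a methoxy group or an amine remains open.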